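Chalcone series: chloro to methoxy step on a rearranged core

The source may hold more compounds than are shown below. What is called first, only, known or untested is meant among the compounds shown, and "the series" means these compounds.

Measured so far in a functional assay on PC-3 cells (Homo sapiens) for antiproliferative activity, read by MTT assay, with a stated time of 48 h; on this read-out lower numbers stand for stronger inhibition and higher numbers for weaker inhibition:
compound 1, `COc1ccc(-c2nn(-c3ccccc3)cc2/C=C/C(=O)c2ccc(OCc3ccccc3)c3c2OC(C)(C)C3)cc1`, 7900 nM
compound 2, `CC1(C)Cc2c(OCc3ccccc3)ccc(C(=O)/C=C/c3cn(-c4ccccc4)nc3-c3ccc(Cl)cc3)c2O1`, 8400 nM
compound 3, `CC1(C)Cc2c(ccc(C(=O)/C=C/c3cn(-c4ccccc4)nc3-c3ccc(Cl)cc3)c2OCc2ccccc2)O1`, 26000 nM

Compound 1 and compound 2 share a core and differ only in one aryl substituent: methoxy in place of chloro on an aromatic carbon. The step of a 1.1-fold lower number from compound 2 to compound 1 (0.03 log units; within the scatter) is small, so on this core the two values show no separation.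

Compound 3 is built from the same atoms as compound 2, joined differently; the difference between the two cores is not broken down here. Compound 3 stands at the highest number of the three, and its distance to compound 2 and to compound 1 lies beyond the scatter in both cases.

Compound 4, `COc1ccc(-c2nn(-c3ccccc3)cc2/C=C/C(=O)c2ccc3c(c2OCc2ccccc2)CC(C)(C)O3)cc1`, is not yet measured. It stands to compound 3 as compound 1 stands to compound 2: methoxy in place of chloro on an aromatic carbon. The place of the change is the same in both pairs, so this is the same change made on the core of compound 3. For the measured compounds named here, only one earlier instance of the change exists, from compound 2 to compound 1, and it was within the scatter; no other compound bears on it.

In this assay compound 4 is therefore expected to sit close to compound 3, with an estimated step of a 1.1-fold lower number from compound 3 to compound 4 (0.03 log units; within the scatter), resting on the small step of a 1.1-fold lower number from compound 2 to compound 1 (0.03 log units; within the scatter). The estimate for compound 4 is 24000 nM, expected to fall between 12000 nM and 48000 nM.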

Compound 4, half-maximal inhibitory concentration: 18400 nM
For compound 4 the middle estimate is 1.3-fold (0.12 log units) above the measured one; the measured number falls inside the stated range.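

In this assay, methoxy in place of chloro on the core of compound 3 gives a 1.4-fold lower number from compound 3 to compound 4 (0.15 log units; within the scatter), and this step does not differ from the earlier one on the other core: the same change on two cores in this assay, a 1.1-fold lower number (0.03 log units; within the scatter) from compound 2 to compound 1 and a 1.4-fold lower number (0.15 log units; within the scatter) from compound 3 to compound 4, 1.3-fold (0.12 log units) apart, within the scatter of two such steps

Across these two pairs, then, the change from 4-chlorophenyl to 4-methoxyphenyl stays within the scatter on both cores, and a small step seen on one core was also seen on the other. This does not show that the change is without effect on any further core or in any other read-out, and since both steps are small, it gives no test of whether a large step would carry over in the same way; nor does it say anything about why the two cores stand apart.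

The compounds shown cover only chloro and methoxy at this place, so it stays open whether an amine, a carboxylic acid or a longer alkoxy chain there would also give matching steps on the two cores. As far as these compounds go, it also stays open whether such groups would leave the distance between the two cores as it stands for the chloro pair, compound 2 and compound 3.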